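Phenyl for 1-benzofuran-2-yl: working notes on four compounds

The source may report more compounds than this note shows. Statements on the series, on what has been measured and on what is new or still open speak of the compounds shown alone.

Measured compounds:
compound 1 `COc1ncnc2c1c(-c1ccccc1)cn2[C@@H]1O[C@H](CO)[C@@H](O)[C@H]1O` gives > 20000 nM in a functional assay on K562 cells (Homo sapiens), read by MTT assay, with a stated time of 72 h (a lower number here means a stronger inhibitor, a higher number a weaker inhibitor), a limit of the assay.
compound 2 `O=c1[nH]cnc2c1c(-c1cc3ccccc3o1)cn2[C@@H]1O[C@H](CO)[C@@H](O)[C@H]1O` gives > 20000 nM in this assay, also a limit.
compound 3 `COc1ncnc2c1c(-c1cc3ccccc3o1)cn2[C@@H]1O[C@H](CO)[C@@H](O)[C@H]1O` gives 13100 nM in this assay.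

Only compound 3 returns a number. The step from compound 3 to compound 1 is an at least 1.5-fold higher number from compound 3 to compound 1 (0.18 log units; that floor lies within the scatter), the change being (phenyl in place of 1-benzofuran-2-yl on an aromatic carbon); its size cannot be fixed more closely because of the limit of > 20000 nM in this assay, at which 2 of the 3 values shown sit. How the core of compound 2 differs from the core of compound 3 is not broken down here; what the two values show is a number for compound 3 and a limit for compound 2.

Compound 4 `O=c1[nH]cnc2c1c(-c1ccccc1)cn2[C@@H]1O[C@H](CO)[C@@H](O)[C@H]1O` is not yet measured. It differs from compound 2 by phenyl in place of 1-benzofuran-2-yl on an aromatic carbon, the same change as from compound 3 to compound 1, at a place described in the same words. The expected step from compound 2 to compound 4 in this assay is a step that the limit leaves unreadable from compound 2 to compound 4, set beside the earlier one; this rests on compound 2 already sitting at the limit > 20000 nM and on the earlier change not lowering the number. Compound 4 is therefore expected to fall at 30000 nM, with a range from 15000 nM to 80000 nM, most likely reported as a limit.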

Compound 4, half-maximal inhibitory concentration: > 20000 nM
Compound 4 ended at the assay's limit (the forecaster's own chance of this, stated with the estimate: 85%); the middle value lies beyond the limit too.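

No new step can be read from compound 2 to compound 4 in this assay, because both compounds stand at a limit rather than a number: the limit of > 20000 nM in this assay, at which 3 of the 4 values shown sit.

The compounds shown leave open how large the change from 1-benzofuran-2-yl to phenyl is on either core, and whether the core of compound 2 responds to it at all.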